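The compounds below may be only part of what the source reports. "The series", "measured", "known", "first", "only" and "open" are said of these compounds alone.

In an ADME assay on microsomes from liver (Mus musculus) for metabolic stability, tested at 5 uM (a higher number here means that the compound lasts longer, a lower number that the compound disappears faster), compound 1 `CCCCCCNc1ccc([N+](=O)[O-])cc1S(N)(=O)=O` gives < 0.0834 h, which is a limit and not a number. Compound 2 `CCCCCCCCNc1ccc([N+](=O)[O-])cc1S(N)(=O)=O` gives < 0.0834 h, also a limit. Compound 3 `CCCCCCNc1ccc([N+](=O)[O-])cc1S(=O)(=O)N(C)C` gives < 0.0834 h, again a limit. The whole record is therefore (the limit of < 0.0834 h in this assay, at which 3 of the 3 values shown sit). Compound 4 `CCCCCCNc1ccc(C(=O)O)cc1S(N)(=O)=O` differs from compound 1 as follows: carboxy in place of nitro on an aromatic carbon, with carboxy in place of nitro on an aromatic carbon. The two measured changes are a step that the two limits leave unreadable from compound 1 to compound 2 and a step that the two limits leave unreadable from compound 1 to compound 3. Neither touches the nitro, so neither gives a size to carry over. A longer half-life is tentatively expected, though another limit remains possible, and the expected change is an at least 2.3-fold higher number from compound 1 to compound 4 (0.37 log units; beyond the scatter). For compound 4 the estimated half-life is 0.2 h, with an expected range from 0.07 h to 1.5 h.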

Compound 4, half-life: > 1 h
Compound 4: only a limit was reported (the forecaster's own chance of this, stated with the estimate: 40%); at least 5.0-fold (0.69 log units) between middle value and limit.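

Among the compounds shown, this position on the aromatic ring is the first place where a change can be read in this assay; the two earlier steps cannot be read. Putting carboxy in place of nitro gives an at least 11-fold higher number from compound 1 to compound 4 (1.07 log units; beyond the scatter) Compound 4 gives > 1 h, which is a limit and not a number.

From the compounds shown here alone, it remains open whether other groups at this position, such as an amide or a nitrile, would also give a longer half-life. Going by these compounds, it also remains open whether carboxy would do so alongside a longer chain or the dimethylamino group of compound 3.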